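Fluorophenyl isoxazole acids on prostate carcinoma cells

A few compounds are considered here, and "the series" means these few. Any claim that something is new, unique, unknown or untested is made for them only; others in the source may bear on it.

Measured so far:
compound 1 `Cc1ccc(-c2cc(COC3(C(F)(F)F)Oc4ccccc4C=C3C(=O)O)on2)cc1` — 41400 nM
compound 2 `O=C(O)C1=Cc2ccccc2OC1(OCc1cc(-c2ccc(F)cc2F)no1)C(F)(F)F` — > 150000 nM

In a functional assay on DU-145 cells (Homo sapiens) for inhibition, read by MTT assay, with a stated time of 24 h (on this read-out lower numbers stand for stronger inhibition and higher numbers for weaker inhibition), compound 1 gives 41400 nM. For compound 2 the entry > 150000 nM is a limit of the assay, not a number. For the measured compounds named here, the one measured step, an at least 3.6-fold higher number from compound 1 to compound 2 (0.55 log units; beyond the scatter), therefore ends at the limit of > 150000 nM in this assay, at which 1 of the 2 values shown sits, and its true size is not fixed. Compound 3 `O=C(O)C1=Cc2ccccc2OC1(OCc1cc(-c2ccc(F)cc2)no1)C(F)(F)F` differs from compound 2 by hydrogen in place of fluoro on an aromatic carbon. Going by the values given here, only that step from compound 1 to compound 2 bears on it, and in structure compound 3 sits between the two: one of the two fluoro groups is kept, the other replaced by hydrogen. Compound 3 is expected to give a number somewhat lower than the limit of compound 2, a step of an at least 1.5-fold lower number from compound 2 to compound 3 (0.17 log units; that floor lies within the scatter) of modest size at most, but it may also remain at the limit. The estimate for compound 3 in this assay is 100000 nM, within 35000 nM to 300000 nM.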

Compound 3, half-maximal inhibitory concentration: 168000 nM
Compound 3: the middle estimate sits 1.7-fold (0.23 log units) below what was measured; measured number inside the range.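

In this assay, for the compounds shown here, the readable change is fluoro in place of methyl on an aromatic carbon, a 4.1-fold higher number from compound 1 to compound 3 (0.61 log units; beyond the scatter) and it needs only the one fluoro group of the 4-fluorophenyl. The second fluoro group of compound 2 is therefore not required for the higher number, and the 4-methylphenyl of compound 1 keeps the lowest measured number of these three. Compound 2 stands at a limit of the assay, > 150000 nM and not a number, so the steps that touch it cannot be read and the weight of the fluoro group ortho to a large group stays unsized: the limit of > 150000 nM in this assay, at which 1 of the 3 values shown sits.

Only methyl, fluoro and hydrogen appear on this aromatic ring, so a methoxy or a chloro group on the same carbon remains an open comparison. From the compounds shown here alone, the shared core is also unchanged throughout, and what an amide in place of the carboxylic acid would give stays open.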